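Ether side chain change in a series at the limit

A few compounds are considered here, and "the series" means these few. Any claim that something is new, unique, unknown or untested is made for them only; others in the source may bear on it.

Values from a functional assay (blood) for inhibition, with Homo sapiens as the target (on this read-out higher numbers stand for weaker inhibition and lower numbers for stronger inhibition), follow, and each one is a limit:
- compound 1 `CC(C)(C)Sc1c(CC(C)(C)C(=O)O)n(Cc2ccc(Cl)cc2)c2ccc(CCc3ccc4ccccc4n3)cc12` gives > 3000 nM
- compound 2 `Cc1nc2ccc(COc3ccc4c(c3)c(SC(C)(C)C)c(CC(C)(C)C(=O)O)n4Cc3ccc(Cl)cc3)cc2s1` gives > 3000 nM
- compound 3 `CC(C)(C)Sc1c(CC(C)(C)C(=O)O)n(Cc2ccc(Cl)cc2)c2ccc(OCc3ccncc3)cc12` gives > 3000 nM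

Compound 3 stands at > 3000 nM and this is a limit, not a number. The whole set shares this position, as the limit of > 3000 nM in this assay, at which 3 of the 3 values shown sit, shows.

Compound 4 `C[C@@H](COc1ccc2c(c1)c(SC(C)(C)C)c(CC(C)(C)C(=O)O)n2Cc1ccc(Cl)cc1)c1ccccn1` differs from compound 3 by 1-(pyridin-2-yl)ethyl in place of pyridin-4-yl on a saturated chain carbon bound to an oxygen on an aromatic ring and so has 1-(pyridin-2-yl)ethyl in place of pyridin-4-yl.

The measured change at this place is a step that the two limits leave unreadable from compound 2 to compound 3 and the other step bearing on it is a step that the two limits leave unreadable from compound 1 to compound 3 with no size to carry over. No direction can therefore be drawn, and no clear step is expected in this assay from these data.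

The expected change is a number no higher from compound 3 to compound 4 (the limit leaves the size open) as an estimate only.

Compound 4 is estimated at 3000 nM with an expected range from 900 nM to 9000 nM and a further limit reading is likely.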

Compound 4, half-maximal inhibitory concentration: 280 nM
The estimate for compound 4 lay 11-fold (1.03 log units) above the measured number; the measured number lies below the stated range.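

In this assay, 1-(pyridin-2-yl)ethyl in place of pyridin-4-yl gives an at least 10-fold lower number from compound 3 to compound 4 (1.02 log units; beyond the scatter). The same compound also shows an at least 10-fold lower number from compound 2 to compound 4 (1.02 log units; beyond the scatter) and an at least 10-fold lower number from compound 1 to compound 4 (1.02 log units; beyond the scatter). Compound 4 therefore shows that this place can move the read-out, and it alone gives a number, while the steps among the other compounds cannot be read: the limit of > 3000 nM in this assay, at which 3 of the 4 values shown sit.

The compounds shown do not separate the effect of the ethyl chain, the pyridin-2-yl attachment and the defined stereocentre. From the compounds shown here alone, how the opposite stereocentre, an amine or a longer chain would read at this place remains open.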